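Swapping a flexible side chain for an aromatic amide

The source may report more compounds than this note shows. Statements on the series, on what has been measured and on what is new or still open speak of the compounds shown alone.

Three compounds share one core. Compound 1 `CC(C)(C)OC(=O)Nc1ncc(C(Oc2ccc(Br)cc2)c2ccc(Cl)cc2)s1` carries a carbamate group on the ring nitrogen. In an ADME assay on HepG2 2.2.15 cells (Homo sapiens) for cytotoxicity (on this read-out lower numbers stand for higher toxicity in this test and higher numbers for lower toxicity in this test), compound 1 reaches only the assay limit, > 50000 nM, which is not a measured number (the limit of > 50000 nM in this assay, at which 1 of the 2 values shown sits). Compound 2 `COC(=O)CCCCNc1ncc(C(Oc2ccc3cc(Br)ccc3c2)c2ccc(Cl)cc2)s1` carries a 4-(methoxycarbonyl)butyl chain on that nitrogen, and in this assay compound 2 is reported as "not toxic" (no number reported), without a number. So compound 2 stands at the non-toxic end of what has been seen, alongside the limit reached by compound 1; nothing between the two compounds can be ranked.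

Compound 3 `COc1ccc(C(=O)Nc2ncc(C(Oc3ccc4cc(Br)ccc4c3)c3ccc(Cl)cc3)s2)cc1` is the new member. Its difference from compound 2 is (4-methoxyphenyl)carbonyl in place of 4-(methoxycarbonyl)butyl on a nitrogen on an aromatic ring. The flexible chain is replaced by an aromatic amide, while the hydrogen-bond acceptor count stays the same.

Going by the values given here, no measured step exists for this kind of change. With both known compounds sitting at or beyond the limit, the expected step in this assay is none beyond the scatter. Compound 3 is therefore estimated at 50000 nM, with a range from 20000 nM to 100000 nM, most likely reported again only as a limit.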

Compound 3, half-maximal cytotoxic concentration: > 50000 nM
Compound 3 ended at the assay's limit (the forecaster's own chance of this, stated with the estimate: 75%); the middle value lies on the limit itself.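

No step can be read from compound 2 to compound 3, as compound 2 has no number in this assay and compound 3 reaches only a limit there: the limit of > 50000 nM in this assay, at which 2 of the 3 values shown sit.

The compounds shown leave open whether replacing 4-(methoxycarbonyl)butyl with (4-methoxyphenyl)carbonyl changes the half-maximal cytotoxic concentration at all.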